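This account rests on a few compounds, and the source may have more. Where it says the series, first, only, none or still open, it means among the compounds named here.

Of the compounds shown here, two have been measured in an assay on HEK293 cells for displacement of a labelled ligand from metabotropic glutamate receptor 5 (Rattus norvegicus); a higher number here means a weaker inhibitor, a lower number a stronger inhibitor. Compound 1 `Cc1ccc(C(=O)Nc2cc(-c3ccccc3)nn2-c2ccccc2)cc1C` gives 430 nM in this assay, while compound 2 `O=C(Nc1cc(-c2ccccc2)nn1-c1ccccc1F)c1ccccc1` gives 2700 nM, the higher of the two numbers, a gap beyond the scatter. Compound 3 `COc1cccc(-n2nc(-c3ccccc3)cc2NC(=O)c2ccccc2)c1` differs from compound 2 in one place: 3-methoxyphenyl in place of 2-fluorophenyl on an aromatic nitrogen. Among the measured compounds shown here, no measured pair shows this change on its own, so only a modest step is expected from compound 2 to compound 3, a 1.5-fold lower number from compound 2 to compound 3 (0.18 log units; within the scatter), toward a somewhat lower number. Compound 3 is therefore estimated at 1800 nM in this assay, with a range from 500 nM to 6500 nM.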

Compound 3, inhibition constant: 2100 nM
For compound 3 the middle estimate is 1.2-fold (0.07 log units) below the measured one, and the stated range covers the measured number.
By their numbers in this assay, from the lowest: compound 1; then compounds 3 and 2 (each within the scatter of the next).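

On the aromatic nitrogen, 3-methoxyphenyl in place of 2-fluorophenyl gives a 1.3-fold lower number from compound 2 to compound 3 (0.11 log units; within the scatter) in this assay. Among the compounds shown here, this is the first direct view of this position, and it shows that this exchange of one substituted phenyl group for another leaves the number within the scatter. No measurement here offers an explanation for this result.

For the compounds shown here, the single step cannot separate the loss of 2-fluorophenyl from the arrival of 3-methoxyphenyl. It also leaves open whether a different group at this position, such as an amine or a carboxylic acid on the phenyl ring, would shift the number beyond the scatter.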